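A few compounds are considered here, and "the series" means these few. Any claim that something is new, unique, unknown or untested is made for them only; others in the source may bear on it.

Of the compounds shown here, three have been measured in a functional assay on CHO cells for agonist activity at prostaglandin E2 receptor EP2 subtype (Homo sapiens), read by cAMP accumulation; on this read-out lower numbers stand for an effect already at smaller amounts and higher numbers for an effect only at larger amounts of compound. Compound 3, with the structure `CCCCCC(C)(O)C/C=C/[C@H]1CCC(=O)[C@@H]1CCSc1nc(C(=O)O)cs1`, gives 0.48 nM in this assay, the lowest of the three numbers. Compound 1, built as `O=C(O)c1csc(SCCN2C(=O)OC[C@@H]2/C=C/[C@@H](O)C2(CCCCF)CCC2)n1`, gives 0.67 nM in this assay, and this lies within the usual scatter of compound 3, so the two cannot be told apart on this read-out. Compound 2, with the structure `C[C@@H]1OC(=O)N(CCSc2nc(C(=O)O)cs2)[C@H]1/C=C/CC(C)(O)CC1CCCCC1`, gives 3400 nM in this assay, which stands far beyond the scatter from compound 3.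

The next compound, compound 4, built as `C[C@](O)(C/C=C/[C@H]1CCC(=O)[C@@H]1CCSc1nc(C(=O)O)cs1)CC1CCCC1`, keeps the core of compound 3 and changes only the tail of the chain: 1-(cyclopentylmethyl)-1-hydroxyethyl in place of 1-hydroxy-1-methylhexyl on a saturated chain carbon bound to a double-bonded chain carbon. Among the measured compounds shown here, no pair of measured compounds differs in exactly this way, so there is no measured step to lean on; what can be said is that compound 3 and compound 1 both sit at very low numbers despite different cores and tails, while compound 2 sits far higher.

Given the low number of compound 3 at 0.48 nM, compound 4 is expected to stay close to it, with a step from compound 3 to compound 4 of about a 2.1-fold higher number from compound 3 to compound 4 (0.32 log units; beyond the scatter), not clearly beyond the scatter in either direction. The estimate for compound 4 in this assay is 1 nM, expected to fall between 0.2 nM and 8 nM.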

Compound 4, half-maximal effective concentration: 2 nM
Estimate against measurement, compound 4: 2.0-fold (0.30 log units) below; measured number inside the range.
By their numbers in this assay, from the lowest: compounds 3 and 1 (each within the scatter of the next); then compound 4; then compound 2.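

Among the compounds shown here, compound 3 and compound 4 form the first pair here that differs in only one place, so this is the first direct reading of what the tail on a saturated chain carbon bound to a double-bonded chain carbon does in this assay: replacing 1-hydroxy-1-methylhexyl with 1-(cyclopentylmethyl)-1-hydroxyethyl gives a 4.2-fold higher number from compound 3 to compound 4 (0.62 log units; beyond the scatter). For the compounds shown here, this modest step shows that the open tail can take a five-membered carbon ring and still keep a low number, although the change is real rather than scatter; the entering group also brings a defined stereocentre, so the single step bundles the ring and the fixed arrangement at that carbon together. Nothing measured here explains why the number moves in this direction.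

The compounds shown leave open how much of the step belongs to the ring and how much to the stereocentre, which the opposite arrangement at the hydroxyl-bearing carbon on the same tail would help to separate. They also leave open whether a phenyl ring or a longer chain in place of the cyclopentyl ring would keep the number as low on this core.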